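Chain-end amine swaps on the benzoxazole aryl ether series

The source may report more compounds than this note shows. Statements on the series, on what has been measured and on what is new or still open speak of the compounds shown alone.

Among the compounds with values here, compound 3 `N[C@H]1CCN(CCCOc2ccc(-c3nc4ccc(Oc5ccc(Cl)cc5)cc4o3)cc2)C1` gives 29.9% in an assay on isolated protein for inhibition of advanced glycosylation end product-specific receptor (Homo sapiens), read by FRET, with stated times of 30 min and 1 h, tested at 4 uM (a lower number here means less inhibition, a higher number more inhibition at the concentration tested (going by the name of the read-out)), and stands highest of the three numbers so far, though its gap to compound 1 `Clc1ccc(Oc2ccc3nc(-c4ccc(OC5CCNCC5)cc4)oc3c2)cc1`, which gives 20.6%, lies within the scatter; only compound 2 `CCN1CCC(COc2ccc(-c3nc4ccc(Oc5ccc(Cl)cc5)cc4o3)cc2)CC1`, which gives 2.1%, sits clearly lower. Compound 4 `CN1CCN(CCCOc2ccc(-c3nc4ccc(Oc5ccc(Cl)cc5)cc4o3)cc2)CC1` is not yet measured. It differs from compound 3 by 4-methylpiperazin-1-yl in place of 3-aminopyrrolidin-1-yl on a saturated chain carbon, three bonds along the chain from an oxygen on an aromatic ring. Within the data shown here, two measured steps bear on this: the change a number 27.8 percentage points higher from compound 2 to compound 3 (beyond the scatter) and the change a number 18.5 percentage points lower from compound 1 to compound 2 (beyond the scatter). In both, the compound carrying a hydrogen-bond donor on the chain-end amine is the higher one, and the donor-free compound 2 has the lowest number of the set. Compound 4 likewise carries no donor on its 4-methylpiperazin-1-yl group, so a modest drop in this assay is expected, of roughly a number 19.9 percentage points lower from compound 3 to compound 4 (beyond the scatter). Compound 4 is therefore estimated at 10%, with a range from 0% to 24%.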

Compound 4, a percentage reported as inhibition, at one concentration (the size of the read-out at that concentration, not a potency): 24.3%
Beside the measured number, compound 4's estimate is 14.3 percentage points below it, and the stated range ends below it.
By their numbers in this assay, from the lowest: compound 2; then compounds 1, 4 and 3 (each within the scatter of the next).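

In this assay the swap at this place gives a number 5.6 percentage points lower from compound 3 to compound 4 (within the scatter), so a chain-end group with 0 hydrogen-bond donors, 4-methylpiperazin-1-yl, stands level with 3-aminopyrrolidin-1-yl, and compound 2 no longer shows that a donor on the chain-end amine is needed. The steps of a number 22.2 percentage points higher from compound 2 to compound 4 (beyond the scatter) and a number 3.7 percentage points higher from compound 1 to compound 4 (within the scatter) point the same way: two compounds without such a donor lie clearly apart, while compound 4 stays level with the donor-bearing compound 1, so donor count alone does not order this set. No measurement on hand accounts for these steps.

On these data alone, the step from compound 2 changes chain and chain-end group at once, so it stays open which of the two carries the difference. A morpholine or dimethylamino group on the same propyl chain, or a longer chain carrying 4-methylpiperazin-1-yl, would separate these.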